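This account rests on a few compounds, and the source may have more. Where it says the series, first, only, none or still open, it means among the compounds named here.

The three measured compounds share one core, an anilide whose aniline carries a sulfonamide to a second aniline. Compound 1 `O=C(Nc1ccc(S(=O)(=O)Nc2ccccc2)cc1)c1ccc(I)cc1F` gives 5130 nM in a functional assay on HEK293 cells for agonist activity at probable G-protein coupled receptor 27 (Homo sapiens), read by a luciferase reporter and beta-arrestin recruitment, with a stated time of 10 min; a lower number here means that less compound is needed, a higher number that more compound is needed for the effect. Compound 2 `Cc1cc(Cl)ccc1C(=O)Nc1ccc(S(=O)(=O)Nc2ccccc2)cc1` gives 912 nM in this assay; the step of a 5.6-fold lower number from compound 1 to compound 2 (0.75 log units; beyond the scatter) arises from the exchange of the group on the carbonyl carbon. Compound 3 `O=C(Nc1ccc(S(=O)(=O)Nc2cccc(Cl)c2)cc1)c1ccc(Cl)cc1Cl` gives 575 nM in this assay, the lowest of the three numbers; it lies within the scatter of compound 2 and well beyond the scatter of compound 1. Compound 3 and compound 2 differ in two places at once, so their two values show only that both sit in the same region.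

Compound 4 `O=C(Nc1ccc(S(=O)(=O)Nc2ccccc2)cc1)c1ccc(Cl)cc1Cl` is not yet measured. It differs from compound 3 by hydrogen in place of chloro on an aromatic carbon, on an aromatic carbon of a six-membered aromatic ring of carbon only, meta to a large group. Going by the values given here, no measured step touches this ring: the only step on record, a 5.6-fold lower number from compound 1 to compound 2 (0.75 log units; beyond the scatter), concerns the group on the carbonyl carbon. Compounds 1 and 2 both carry the plain anilino and reach the region of compound 3 only with the 4-chloro-2-methylphenyl group, which gives no direct guide. The account therefore expects for compound 4 a small step of a 1.5-fold higher number from compound 3 to compound 4 (0.17 log units; within the scatter), if any, toward a higher number. Compound 4 is estimated at 850 nM, expected between 300 nM and 2500 nM.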

Compound 4, half-maximal effective concentration: 457 nM
Estimate against measurement, compound 4: 1.9-fold (0.27 log units) above; measured number inside the range.
By their numbers in this assay, from the lowest: compounds 4, 3 and 2 (each within the scatter of the next); then compound 1.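

In this assay, the exchange of (3-chlorophenyl)amino for anilino gives a 1.3-fold lower number from compound 3 to compound 4 (0.10 log units; within the scatter), the first step read at this position, and it shows that with the 2,4-dichlorophenyl group on the carbonyl carbon, hydrogen and chloro on this ring cannot be told apart. With the plain anilino now held fixed across compounds 1, 2 and 4, the group on the carbonyl carbon can be compared three ways: chloro in place of methyl gives a 2.0-fold lower number from compound 2 to compound 4 (0.30 log units; within the scatter), while 2,4-dichlorophenyl in place of 2-fluoro-4-iodophenyl gives an 11-fold lower number from compound 1 to compound 4 (1.05 log units; beyond the scatter), so among these three only the 2-fluoro-4-iodophenyl compound stands apart. Nothing available here accounts for the size of any of these steps.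

Only hydrogen and chloro are shown at this position, so what a methoxy group, an amine or a carboxylic acid would do there remains open. On these data alone, the step is also read only alongside the 2,4-dichlorophenyl group, and whether it stays as small with 4-chloro-2-methylphenyl or 2-fluoro-4-iodophenyl on the carbonyl carbon is unknown.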